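Iodo in place of methoxy on the shared core of compound 1

This account rests on a few compounds, and the source may have more. Where it says the series, first, only, none or still open, it means among the compounds named here.

Compound 1, `COc1ccc(-n2cc(COc3cccc(NC(=O)Nc4ccc(Cl)c(C(F)(F)F)c4)c3)nn2)cc1`: 4680 nM in a functional assay on HepG2 cells (Homo sapiens) for inhibition, read by MTT assay, with a stated time of 72 h; on this read-out higher numbers stand for weaker inhibition and lower numbers for stronger inhibition
Compound 2, `CCc1cccc(-n2cc(COc3cccc(NC(=O)Nc4ccc(Cl)c(C(F)(F)F)c4)c3)nn2)c1`: 37900 nM
Compound 3, `CC(C)c1cccc(-n2cc(COc3cccc(NC(=O)Nc4ccc(Cl)c(C(F)(F)F)c4)c3)nn2)c1`: 3250 nM

Compound 1 stands second highest of these three numbers, with compound 3 within the scatter of it and compound 2 well apart: an 8.1-fold higher number from compound 1 to compound 2 (0.91 log units; beyond the scatter). Compound 4, `O=C(Nc1cccc(OCc2cn(-c3ccc(I)cc3)nn2)c1)Nc1ccc(Cl)c(C(F)(F)F)c1`, differs from compound 1 in one place: iodo in place of methoxy on an aromatic carbon. The measured steps that bear on this all alter the same 4-methoxyphenyl group on the shared core: an 8.1-fold higher number from compound 1 to compound 2 (0.91 log units; beyond the scatter), a 1.4-fold lower number from compound 1 to compound 3 (0.16 log units; within the scatter), and between the two ethyl and isopropyl compounds a 12-fold lower number from compound 2 to compound 3 (1.07 log units; beyond the scatter). From the compounds shown here alone, none of them exchanges methoxy for iodo, so the direction stays open, and changes at this group have gone both ways. A step within the scatter is therefore expected for compound 4: a 1.2-fold lower number from compound 1 to compound 4 (0.07 log units; within the scatter). Compound 4 is estimated at 4000 nM, with a range from 1000 nM to 16000 nM.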

Compound 4, half-maximal inhibitory concentration: 2690 nM
Compound 4: middle estimate off by 1.5-fold (0.17 log units), on the high side; the measured number falls inside the stated range.
By their numbers in this assay, from the lowest: compounds 4, 3 and 1 (each within the scatter of the next); then compound 2.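

Iodo, a single heavy atom, stands in for the two-atom methoxy at this place without moving the number beyond the scatter (a 1.7-fold lower number from compound 1 to compound 4 (0.24 log units; within the scatter)). Compound 4 also stays within the scatter of the 3-isopropylphenyl compound (a 1.2-fold lower number from compound 3 to compound 4 (0.08 log units; within the scatter)), while the 3-ethylphenyl compound remains far apart (a 14-fold lower number from compound 2 to compound 4 (1.15 log units; beyond the scatter)), making it the only one of these four that stands apart. No measurement here explains why these groups give such similar or such different numbers.

From the compounds shown here alone, whether an amine or a carboxylic acid in place of iodo would keep the number at this level remains open.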